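A few compounds are considered here, and "the series" means these few. Any claim that something is new, unique, unknown or untested is made for them only; others in the source may bear on it.

In a functional assay on MCF7 cells (Homo sapiens) for inhibition, read by sulforhodamine B assay (on this read-out lower numbers stand for stronger inhibition of growth and higher numbers for weaker inhibition of growth), compound 2 (`COc1ccc(-c2ccc(-c3ccc(-c4nc5ccccc5[nH]4)cc3)cc2)cc1OC`) stands highest of the two measured compounds at 7600 nM, while compound 1 (`COc1cc(-c2ccc(-c3ccc(-c4nc5cc(C)ccc5[nH]4)cc3)cc2)cc(OC)c1OC`) gives 170 nM, a gap beyond the scatter. Those two compounds differ in more than one place. Compound 3 (`COc1cc(-c2ccc(-c3ccc(-c4nc5ccccc5[nH]4)cc3)cc2)cc(OC)c1OC`) departs from compound 2 by a single change, methoxy in place of hydrogen on an aromatic carbon. Compound 1, which also carries this methoxy, reads 170 nM, so a lower number, meaning stronger inhibition of growth, is expected in this assay. The expected step, beyond the scatter, is a 19-fold lower number from compound 2 to compound 3 (1.28 log units; beyond the scatter). For compound 3 the estimated value is 400 nM, within an expected range of 100 nM to 2000 nM.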

Compound 3, concentration for 50% growth inhibition: 6380 nM
Compound 3: the middle estimate sits 16-fold (1.20 log units) below what was measured, outside the stated range (above it).
By their numbers in this assay, from the lowest: compound 1; then compounds 3 and 2 (each within the scatter of the next).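

Methoxy in place of hydrogen at this place gives only a 1.2-fold lower number from compound 2 to compound 3 (0.08 log units; within the scatter) in this assay and so does not by itself account for the low number of compound 1. Hydrogen in place of methyl gives a 38-fold higher number from compound 1 to compound 3 (1.57 log units; beyond the scatter) and is the step that carries the large change here. No measured evidence bearing on either step is available. The compounds shown leave open whether an ethyl group, a chlorine atom or an amine could stand in for that methyl, and whether the methyl gives the same large step without this methoxy.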